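A Pyrrolyl Group Added to Compound 1

The source may hold more compounds than are shown below. What is called first, only, known or untested is meant among the compounds shown, and "the series" means these compounds.

Going by the values given here, in an ADME assay on cells (Macrophage, Mus musculus) for cytotoxicity, read by resazurin assay, with a stated time of 3 days (on this read-out higher numbers stand for weaker inhibition and lower numbers for stronger inhibition), compound 1 `O=C(Nc1cc(C(F)(F)F)cc(C(F)(F)F)c1)c1ccccc1O` gives 12000 nM, the only exact number in this small set. Compound 2 `O=C(Nc1cc(C(F)(F)F)cc(C(F)(F)F)c1)c1cccc(Cl)c1` gives > 60000 nM, which is a limit of the assay. For compound 3 `O=C(Nc1cc(C(F)(F)F)cc(C(F)(F)F)c1)c1ccccc1` the entry reads "not determined" (no result reported). Compound 4 `O=C(Nc1cc(C(F)(F)F)cc(C(F)(F)F)c1)c1cc(-n2cccc2)ccc1O` is compound 1 with one addition: 1H-pyrrol-1-yl in place of hydrogen on an aromatic carbon. The new 1H-pyrrol-1-yl sits para to the hydroxy group. Among the compounds with values here, the only measured step, an at least 5.0-fold higher number from compound 1 to compound 2 (0.69 log units; beyond the scatter), replaces the whole 2-hydroxyphenyl group, whereas compound 4 keeps its hydroxy group, so that step offers only a loose guide. The estimated step is a 1.3-fold lower number from compound 1 to compound 4 (0.12 log units; within the scatter), so no change beyond the scatter is expected. For compound 4 the expected value is 9000 nM, within an estimated range from 3000 nM to 30000 nM.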

Compound 4, half-maximal inhibitory concentration: 3100 nM
The estimate for compound 4 lay 2.9-fold (0.46 log units) above the measured number; low and high end bracket the measured number.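

Adding 1H-pyrrol-1-yl para to a hydroxy group gives a 3.9-fold lower number from compound 1 to compound 4 (0.59 log units; beyond the scatter) in this assay. The earlier step replaced the whole 2-hydroxyphenyl group, whereas this change keeps the hydroxy group and shows that an addition at this one position is enough to move the number beyond the scatter. Nothing measured here accounts for this step. Open, as far as these compounds go, is whether the five-membered aromatic ring itself matters, or whether a methyl group or an amine at the same position would move the number in the same direction.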